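Replacing a hydroxyphenyl group with a bromophenyl group

The compounds below may be only part of what the source reports. "The series", "measured", "known", "first", "only" and "open" are said of these compounds alone.

Three measured compounds share one core and differ only in the group on the carbonyl carbon. Compound 1 `COc1cc(-c2nnc3n2NC(c2ccco2)C(C(=O)c2ccc(Cl)cc2)S3)cc(OC)c1OC` gives 78600 nM in a functional assay on HepG2 cells (Homo sapiens) for cytotoxicity, read by MTT assay, with a stated time of 48 h; a higher number here means a weaker inhibitor, a lower number a stronger inhibitor. Compound 2 `COc1cc(-c2nnc3n2NC(c2ccco2)C(C(=O)c2ccc(C)cc2)S3)cc(OC)c1OC` gives 17400 nM in this assay. Compound 3 `COc1cc(-c2nnc3n2NC(c2ccco2)C(C(=O)c2ccc(O)cc2)S3)cc(OC)c1OC` reaches only the limit of this assay, reported as > 100000 nM, so no exact number is known for compound 3 (the limit of > 100000 nM in this assay, at which 1 of the 3 values shown sits). Compound 4 `COc1cc(-c2nnc3n2NC(c2ccco2)C(C(=O)c2cccc(Br)c2)S3)cc(OC)c1OC` carries 3-bromophenyl in place of 4-hydroxyphenyl on a carbonyl carbon. For the measured compounds named here, two measured steps bear on this change: an at least 1.2-fold higher number from compound 1 to compound 3 (0.10 log units; that floor lies within the scatter), and an at least 5.7-fold higher number from compound 2 to compound 3 (0.75 log units; beyond the scatter). Swapping the hydroxy for a halogen thus points back toward the number of compound 1, a modest downward step whose size stays uncertain while compound 3 is known only as a limit. Compound 4 is expected near 70000 nM, between 25000 nM and 200000 nM, which is a step of an at least 1.4-fold lower number from compound 3 to compound 4 (0.15 log units; that floor lies within the scatter).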

Compound 4, half-maximal inhibitory concentration: > 100000 nM
Compound 4 gave a limit, no number (the forecaster's own chance of this, stated with the estimate: 35%); middle value at least 1.4-fold (0.15 log units) away from the limit.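

Compound 4, like compound 3, stands at a limit of this assay and not at a number, so 3-bromophenyl on this carbonyl carbon does not by itself give a readable value: the limit of > 100000 nM in this assay, at which 2 of the 4 values shown sit.

With two limits, the step between compound 3 and compound 4 cannot be read. Against 4-methylphenyl the change is clear, with an at least 5.7-fold higher number from compound 2 to compound 4 (0.75 log units; beyond the scatter), but against 4-chlorophenyl it is not, with only an at least 1.2-fold higher number from compound 1 to compound 4 (0.10 log units; that floor lies within the scatter).

Bromine and its place on the ring change together here, so neither can be judged alone. From the compounds shown here alone, how an amine or a carboxylic acid on this phenyl ring would read remains open.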